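Chloro on the benzyl group: notes on four compounds

The compounds below may be only part of what the source reports. "The series", "measured", "known", "first", "only" and "open" are said of these compounds alone.

Measured compounds:
compound 1 `CC1=C(C(=O)Nc2ccc(Br)cc2)C(c2ccc(Cl)cc2Cl)N=C(SCc2ccccc2)N1` — 24.2%
compound 2 `CC1=C(C(=O)Nc2ccc(Br)cc2)C(c2ccc(Cl)cc2Cl)N=C(SCc2ccc(Cl)cc2)N1` — 39.7%
compound 3 `CC1=C(C(=O)Nc2ccc([N+](=O)[O-])cc2)C(c2cccc([N+](=O)[O-])c2)N=C(SCc2ccccc2)N1` — 32.5%

In a functional assay on the whole organism (artery, strain albino) with Rattus norvegicus as the target, with a stated time of 360 min, at a dose of 10 mg/kg by the oral route (a lower number here means less inhibition, a higher number more inhibition at the dose given (going by the name of the read-out)), compound 1 gives 24.2%, and compound 2 gives 39.7%. The change from compound 1 to compound 2 is chloro in place of hydrogen on an aromatic carbon; it made a step of a number 15.5 percentage points higher from compound 1 to compound 2 (beyond the scatter). Compound 3, in this assay, gives 32.5%, which lies within the scatter of both compound 1 and compound 2, so no order among compound 3 and these two can be read from the numbers. The difference between the core of compound 1 and the core of compound 3 is not broken down here.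

Compound 4 `CC1=C(C(=O)Nc2ccc([N+](=O)[O-])cc2)C(c2cccc([N+](=O)[O-])c2)N=C(SCc2ccccc2Cl)N1` is not yet measured. It differs from compound 3 by chloro in place of hydrogen on an aromatic carbon. This is the same kind of change as that from compound 1 to compound 2, but not the same: in compound 2 the chloro sits para to a large group, in compound 4 it sits ortho to a large group. Going by the values given here, the only guide is the single step seen once, a number 15.5 percentage points higher from compound 1 to compound 2 (beyond the scatter), on a different core and at a different place on the ring; how far it carries over to the ortho position and to the core of compound 3 is not known from these data.

The step expected from compound 3 to compound 4 in this assay is estimated at a number 9.5 percentage points higher from compound 3 to compound 4 (within the scatter), smaller than the measured one and with wide bounds. Compound 4 is estimated to give 42% in this assay, with an expected range from 27% to 58%.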

Compound 4, a percentage reported as inhibition, in the whole organism at one dose (the size of the read-out at that dose, not a potency): 17.5%
Estimate against measurement, compound 4: 24.5 percentage points above; measured number below the stated range.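

In this assay, chloro in place of hydrogen on an aromatic carbon of the benzyl group does not keep its direction from one core to another among the compounds shown: the same change on two cores in this assay, a number 15.5 percentage points higher (beyond the scatter) from compound 1 to compound 2 and a number 15 percentage points lower (beyond the scatter) from compound 3 to compound 4, 30.5 percentage points apart, beyond the scatter of two such steps

On the core of compound 3, the change from benzyl to 2-chlorobenzyl gives a number 15 percentage points lower from compound 3 to compound 4 (beyond the scatter), so the rise seen on the core of compound 1 cannot be taken as a guide to other cores in this series. These steps do not show whether the core or the place of the chloro sets the direction: the chloro of compound 4 sits ortho to a large group, the chloro of compound 2 sits elsewhere on the ring, the two cores differ in more than one place, and each step has been seen only once.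

The compounds shown leave open what the 2-chlorobenzyl group gives on the core of compound 1, and what the chloro placed as in compound 2 gives on the core of compound 3, the two comparisons that would separate core from place. Also open, on these data alone, is how a fluoro or methoxy group on the benzyl ring, or a longer chain in place of benzyl on the sulfur, would behave on either core.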